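Replacing 1,3-dicarboxypropyl with (pyridin-4-yl)methyl on an amide

This account rests on a few compounds, and the source may have more. Where it says the series, first, only, none or still open, it means among the compounds named here.

Measured compounds:
compound 1 `Nc1nc2[nH]c(CCSCC(=O)N[C@@H](CCC(=O)O)C(=O)O)cc2c(=O)[nH]1` gives 442 nM
compound 2 `Nc1nc2[nH]c(CCSCCC(=O)NCc3cccnc3)cc2c(=O)[nH]1` gives 665 nM

Within the data shown here, in a functional assay on SW-620 cells (Homo sapiens) for antiproliferative activity, read by MTT assay, with a stated time of 72 h, in the presence of a further agent that is not named here (a lower number here means a stronger inhibitor, a higher number a weaker inhibitor), compound 1 stands within the usual scatter of compound 2, the only other measured compound, so the two cannot be ranked. Compound 3 `Nc1nc2[nH]c(CCSCC(=O)NCc3ccncc3)cc2c(=O)[nH]1` differs from compound 1 in one place: (pyridin-4-yl)methyl in place of 1,3-dicarboxypropyl on an amide-type nitrogen. Among the measured compounds shown here, no measured pair differing in one place gives a guide to this change. With compound 2 at 665 nM as the nearest reference, no step beyond the scatter is expected, in either direction. The estimate amounts to an expected 1.4-fold higher number from compound 1 to compound 3 (0.13 log units; within the scatter). For compound 3 the expected value is 600 nM, with an estimated range from 200 nM to 1800 nM.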

Compound 3, half-maximal inhibitory concentration: 22700 nM
Compound 3: the middle estimate sits 38-fold (1.58 log units) below what was measured, outside the stated range (above it).
By their numbers in this assay, from the lowest: compounds 1 and 2 (each within the scatter of the next); then compound 3.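

In this assay, the group on the amide-type nitrogen proves decisive: (pyridin-4-yl)methyl in place of 1,3-dicarboxypropyl gives a 51-fold higher number from compound 1 to compound 3 (1.71 log units; beyond the scatter). Among these compounds, this is the first readable step on the shared core, and it shows that this position does not accept every group equally. Nothing measured here accounts for the loss. From the compounds shown here alone, it remains open whether a single carboxylic acid on this nitrogen would keep the number of compound 1, and whether a phenylmethyl group would match compound 3 or differ from it.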